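This account rests on a few compounds, and the source may have more. Where it says the series, first, only, none or still open, it means among the compounds named here.

Working notes on the series.

Compound 3 `COc1cc(O)c(C(=O)c2ccccc2F)c(OC)c1` stands lowest of the three measured compounds in a functional assay on THP-1 cells (Homo sapiens) for inhibition, read by ELISA, with stated times of 30 min and 24 h, tested at 10 uM (on this read-out higher numbers stand for a stronger effect at the one concentration tested and lower numbers for a weaker effect), where compound 3 gives 71%. Compound 1 `COc1cc(OC)c(C(=O)c2cccc(Cl)c2)c(O)c1CN1CCCCC1` gives 83% in this assay, and compound 2 `COc1cc(OC)c(C(=O)c2ccccc2Br)c(O)c1CN1CCCCC1` gives 98%; both values lie beyond the scatter above that of compound 3. For the measured compounds named here, the only measured single-point step, a number 15 percentage points higher from compound 1 to compound 2 (beyond the scatter), concerns the halogenated phenyl on the carbonyl carbon and not the change considered here.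

Compound 4 `COc1cc(OC)c(C(=O)c2ccccc2F)c(O)c1CN1CCCCC1` differs from compound 3 by (piperidin-1-yl)methyl in place of hydrogen on an aromatic carbon. Going by the values given here, no measured pair isolates this change: compounds 1 and 2 both carry the (piperidin-1-yl)methyl group but also differ from compound 3 in the halogenated phenyl. What the values show is that the two compounds bearing the group sit higher than compound 3, which lacks it. On that basis compound 4 is expected to land above compound 3, with an estimated step of a number 14 percentage points higher from compound 3 to compound 4 (beyond the scatter). The estimate for compound 4 in this assay is 85%, with a range from 70% to 98%.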

Compound 4, a percentage reported as activity, at one concentration (the size of the read-out at that concentration, not a potency): 84%
Estimate against measurement, compound 4: 1 percentage points above; measured number inside the range.
By their numbers in this assay, from the lowest: compound 3; then compounds 1 and 4 (each within the scatter of the next); then compound 2.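

The matched pair isolates the (piperidin-1-yl)methyl group on this aromatic carbon, ortho to a hydroxy group, with the 2-fluorophenyl held fixed: a number 13 percentage points higher from compound 3 to compound 4 (beyond the scatter) in this assay. With that group in place, the phenyl on the carbonyl also matters, but not for every swap: fluoro in place of bromo gives a number 14 percentage points lower from compound 2 to compound 4 (beyond the scatter) on this read-out, whereas 2-fluorophenyl in place of 3-chlorophenyl gives a number 1 percentage points higher from compound 1 to compound 4 (within the scatter) and separates nothing. No evidence at hand bears on why these numbers move.

The compounds shown leave open whether the step from hydrogen to (piperidin-1-yl)methyl has the same size with 2-bromophenyl or 3-chlorophenyl on the carbonyl. They also leave open whether another amine, such as morpholine, or a longer chain to the piperidine would hold the number.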